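A few compounds are considered here, and "the series" means these few. Any claim that something is new, unique, unknown or untested is made for them only; others in the source may bear on it.

In a functional assay on MCF7 cells (Homo sapiens) for inhibition (a higher number here means a weaker inhibitor, a lower number a stronger inhibitor), compound 1 `CC/C(=C(/c1ccc(/C=C/C(=O)O)cc1)c1cc2ccccc2[nH]1)c1ccccc1Cl` gives 42 nM, and compound 2 `CC/C(=C(/c1ccc(/C=C/C(=O)O)cc1)c1cc2ccccc2[nH]1)c1cccc(Cl)c1Cl` gives 898 nM. Going by the values given here, compound 2 therefore holds the highest of the two numbers; its nearest neighbour is compound 1, and the only step between them, a 21-fold higher number from compound 1 to compound 2 (1.33 log units; beyond the scatter), lies beyond the scatter. Compound 3 `CC/C(=C(/c1ccc(/C=C/C(=O)O)cc1)c1cc2ccccc2[nH]1)c1ccc(C(F)(F)F)cc1Cl` has not been measured in this assay. It differs from compound 2 by 2-chloro-4-(trifluoromethyl)phenyl in place of 2,3-dichlorophenyl on a double-bonded chain carbon bound to a double-bonded chain carbon and a saturated chain carbon. Among the compounds with values here, the step from compound 1 to compound 2 is the only measured one that bears on this change, and it was large; compound 3 gives up the chlorine that compound 2 added, yet carries a trifluoromethyl for which the data hold no step at all. The expected step is a 3.6-fold lower number from compound 2 to compound 3 (0.56 log units; beyond the scatter), back toward compound 1 without reaching it. For compound 3 the estimate in this assay is 250 nM, with a range from 60 nM to 1000 nM.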

Compound 3, half-maximal inhibitory concentration: 27 nM
Compound 3: middle estimate off by 9.3-fold (0.97 log units), on the high side; the whole stated range lies above it.
By their numbers in this assay, from the lowest: compounds 3 and 1 (each within the scatter of the next); then compound 2.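

In this assay the exchange of 2,3-dichlorophenyl for 2-chloro-4-(trifluoromethyl)phenyl gives a 33-fold lower number from compound 2 to compound 3 (1.52 log units; beyond the scatter) and shows that the loss seen with the extra chlorine does not extend to every added group on this phenyl. Trifluoromethyl in place of hydrogen gives only a 1.6-fold lower number from compound 1 to compound 3 (0.19 log units; within the scatter) and so leaves the number unchanged within the scatter, while chloro in place of hydrogen gave a 21-fold higher number from compound 1 to compound 2 (1.33 log units; beyond the scatter) on the same phenyl. No measurement here explains why these two additions part so sharply. On these data alone, whether the difference follows the group or the carbon it sits on stays open, as the two additions differ in both. A 2,4-dichlorophenyl would separate these two readings, and a methoxy or a nitrile in the place of the trifluoromethyl would show how widely that carbon accepts other groups.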